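The source may hold more compounds than are shown below. What is called first, only, known or untested is meant among the compounds shown, and "the series" means these compounds.

Measured in an ADME assay on 2209-23 cells (Homo sapiens) for cytotoxicity, read by WST assay and thymidine incorporation; a higher number here means that more compound is tolerated, a lower number that less compound is tolerated:
- compound 1 `CC(C)(C)CCN1C(=O)C(C2=CS(=O)(=O)c3cc(NS(C)(=O)=O)ccc3N2)=C(O)[C@@H]1C(C)(C)C`: > 50000 nM (a limit)
- compound 2 `CC(=O)C1=C(C2=C(O)[C@H](C(C)(C)C)N(Cc3ccc(F)cc3)C2=O)Nc2ccc(NS(C)(=O)=O)cc2S1(=O)=O`: > 50000 nM (a limit)
- compound 3 `CC(C)(C)[C@H]1C(O)=C(C2=CS(=O)(=O)c3cc(F)ccc3N2)C(=O)N1Cc1ccc(F)cc1`: > 50000 nM (a limit)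

The measured set gives no numerical reading so far, and its position is summed up as the limit of > 50000 nM in this assay, at which 3 of the 3 values shown sit. Compound 3 stands at > 50000 nM, which is a limit of this assay and not a number. The true half-maximal cytotoxic concentration of compound 3 therefore remains unresolved, and no ranking within the set is possible.

The next compound is compound 4 `CC(C)(C)[C@H]1C(O)=C(C2=CS(=O)(=O)c3cc(C#N)ccc3N2)C(=O)N1Cc1ccc(F)cc1`, which carries cyano in place of fluoro on an aromatic carbon. The rest of the structure of compound 3 is retained. Going by the values given here, no step between measured compounds is available to size this change directly, so the expectation draws only on the three limit readings. The expected result, a number no higher from compound 3 to compound 4 (the limit leaves the size open), is no change beyond the scatter in this assay, with no direction favoured. A further report at the limit is expected as the most likely outcome.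

For compound 4 the estimated value is 50000 nM. For compound 4 the expected range runs from 25000 nM to 100000 nM.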

Compound 4, half-maximal cytotoxic concentration: > 50000 nM
Compound 4 was reported as a limit (the forecaster's own chance of this, stated with the estimate: 85%); the middle value sits exactly at the limit.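

In this assay no step can be read from compound 3 to compound 4, as both are reported as limits and the size of the change from fluoro to cyano stays unreadable. The compounds shown leave open where any true half-maximal cytotoxic concentration lies and how they rank, because all share one limit: the limit of > 50000 nM in this assay, at which 4 of the 4 values shown sit.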